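This account rests on a few compounds, and the source may have more. Where it says the series, first, only, none or still open, it means among the compounds named here.

Working notes on the series in a functional assay on the whole organism for inhibition, with Rattus norvegicus as the target, at a dose of 50 mg/kg by the oral route; on this read-out lower numbers stand for less inhibition and higher numbers for more inhibition at the one dose given (going by the name of the read-out). Compound 1 `CCOC(=O)c1c(CSc2nccn2CC)nc2cc(OC)c(OC)cc2c1-c1ccc(OC)c(OC)c1` gives 51% in this assay. Compound 2 `COC(=O)c1c(CSc2nccn2C)nc2cc(OC)c(OC)cc2c1-c1ccc(OC)c(OC)c1` gives 67%. Compound 3 `CCOC(=O)c1c(CSc2nccn2C)nc2cc(OC)c(OC)cc2c1-c1ccc(OC)cc1` gives 64%, the second highest of the three numbers: the nearest is compound 2, whose value lies within the scatter of compound 3, and the furthest is compound 1, whose value lies below compound 3 by more than the scatter. Compound 4 `CCOC(=O)c1c(CSc2nccn2C)nc2cc(OC)c(OC)cc2c1-c1ccccc1` is not yet measured. It differs from compound 3 in one place: hydrogen in place of methoxy on an aromatic carbon. For the measured compounds named here, no step between measured compounds isolates this change, so the expected step of a number 9 percentage points lower from compound 3 to compound 4 (within the scatter) is small, a modest fall within the scatter. For compound 4 the estimate is 55%, with a range from 35% to 75%.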

Compound 4, a percentage reported as inhibition, in the whole organism at one dose (the size of the read-out at that dose, not a potency): 31%
Compound 4: middle estimate off by 24 percentage points, on the high side, and the stated range ends above it.
By their numbers in this assay, from the lowest: compound 4; then compound 1; then compounds 3 and 2 (each within the scatter of the next).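

Going from 4-methoxyphenyl to phenyl gives a number 33 percentage points lower from compound 3 to compound 4 (beyond the scatter) in this assay, a large step from one small change. For the compounds shown here, the methoxy on this aromatic carbon, para to a large group, therefore matters to the read-out at this dose, which the earlier compounds could not show because none of them isolated this place. Hydrogen does not serve here as an equal of methoxy.

Going by these compounds, whether a hydroxyl, an amine or a longer alkoxy chain at this place would hold the read-out remains open. Nothing available bears on the reason for this fall.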